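The source may report more compounds than this note shows. Statements on the series, on what has been measured and on what is new or still open speak of the compounds shown alone.

Measured compounds:
- compound 1 `CCCCOC(=O)NS(=O)(=O)c1ccc(CCC)cc1-c1ccc(Cn2c(C3CC3)nc3ccccc32)cc1` gives 31 nM
- compound 2 `CCCc1ccc(S(=O)(=O)NC(=O)OCCCC(F)(F)F)c(-c2cc(F)c(Cn3c(C(C)(C)C)nc4ccccc43)c(F)c2)c1` gives 12 nM
- compound 3 `CCCCOC(=O)NS(=O)(=O)c1ccc(CCC)cc1-c1cc(F)c(Cn2c(C(C)(C)C)nc3ccccc32)c(F)c1` gives 11 nM

These three values come from an assay on membranes from HEK293 cells for displacement of a labelled ligand from Type-2 angiotensin II receptor (Homo sapiens), read by radioligand binding; a lower number here means a stronger inhibitor, a higher number a weaker inhibitor. For the measured compounds named here, compound 1 stands highest of the three numbers; the one measured step is a 1.1-fold lower number from compound 2 to compound 3 (0.04 log units; within the scatter), a step that changes only the carbamate chain and stays within the scatter. Compounds 2 and 3 differ from compound 1 in more than one place at once, so their gap to compound 1 cannot be assigned to any single change.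

The unmeasured compound 4 `CCCCOC(=O)NS(=O)(=O)c1ccc(CCC)cc1-c1ccc(Cn2c(-c3ccccc3)nc3ccccc32)cc1` is reached from compound 1 by a single change: phenyl in place of cyclopropyl on an aromatic carbon. Going by the values given here, no measured step touches this position of the shared core, and the one step that has been measured concerns a different part of the molecule. There is therefore no direct guide to the direction or size of the step from compound 1 to compound 4, and the estimate must rest on the value of compound 1 alone with a wide range. The writer expects compound 4 to give about 40 nM in this assay, between 10 nM and 160 nM, which is a 1.3-fold higher number from compound 1 to compound 4 (0.11 log units; within the scatter) and is expected to stay close to compound 1.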

Compound 4, inhibition constant: 590 nM
Beside the measured number, compound 4's estimate is 15-fold (1.17 log units) below it, outside the stated range (above it).
By their numbers in this assay, from the lowest: compounds 3 and 2 (each within the scatter of the next); then compound 1; then compound 4.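

In this assay, the aromatic carbon between two ring nitrogen atoms proves sensitive to the group it carries: phenyl in place of cyclopropyl gives a 19-fold higher number from compound 1 to compound 4 (1.28 log units; beyond the scatter). For the compounds shown here, the only single-place step measured earlier concerned the carbamate chain, so this is the first direct reading at this position of the shared core, and it shows that a change here can produce a large step. The two groups have the same counts of hydrogen-bond donors and acceptors, both zero, and no net charge, but they differ in ring size, in aromatic character and in heavy atoms, and nothing available here explains the loss of binding.

Going by these compounds, one step cannot separate ring size from aromatic character, so it remains open where an isopropyl, cyclobutyl, cyclohexyl or pyridyl group would fall relative to cyclopropyl and phenyl. Compound 2 and compound 3 carry a tert-butyl group at this position, but they also differ from compound 1 elsewhere, so their values do not show how tert-butyl alone compares with cyclopropyl.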